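The source may report more compounds than this note shows. Statements on the series, on what has been measured and on what is new or still open speak of the compounds shown alone.

Compound 1 `COc1cc(-c2nn(-c3cccc(NC(=O)Nc4cc(C(F)(F)F)cc(C(F)(F)F)c4)c3)cc2-c2ccncc2)ccc1Cl` and compound 2 `O=C(Nc1cccc(-n2cc(-c3ccncc3)c(-c3ccc(Cl)c(O)c3)n2)c1)Nc1cc(C(F)(F)F)cc(C(F)(F)F)c1` share one core and differ in a single place: hydrogen in place of methyl on an oxygen on an aromatic ring. In a functional assay on BT-549 cells (Homo sapiens) for inhibition, read by sulforhodamine B assay, with a stated time of 48 h (on this read-out lower numbers stand for higher toxicity in this test and higher numbers for lower toxicity in this test), compound 1 gives 29600 nM. In this assay compound 2 gives 4110 nM. The change therefore brought a 7.2-fold lower number from compound 1 to compound 2 (0.86 log units; beyond the scatter).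

Compound 3 `COc1cc(-c2nn(-c3cccc(NC(=O)Nc4ccc(Cl)c(C(F)(F)F)c4)c3)cc2-c2ccncc2)ccc1Cl` is built on a different core; how the two cores differ is not broken down here. In this assay compound 3 gives only a limit, > 32500 nM, and no number. That value sits at the limit of > 32500 nM in this assay, at which 1 of the 3 values shown sits.

Compound 4 `O=C(Nc1cccc(-n2cc(-c3ccncc3)c(-c3ccc(Cl)c(O)c3)n2)c1)Nc1ccc(Cl)c(C(F)(F)F)c1` has not yet been measured in this assay. For the measured compounds named here, it differs from compound 3 by hydrogen in place of methyl on an oxygen on an aromatic ring, and this is the same change as the one from compound 1 to compound 2, made at the same place on the ring, with aromatic carbon as the other neighbour in both cases.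

The account rests on a single measured step, and on a starting point for compound 3 that is known only as a limit. The expectation is nevertheless that the change will act in the same direction and with a comparable size, that is a step estimated as an at least 4.6-fold lower number from compound 3 to compound 4 (0.66 log units; beyond the scatter), drawing on a 7.2-fold lower number from compound 1 to compound 2 (0.86 log units; beyond the scatter) between compound 1 and compound 2. On that basis compound 4 is expected to give about 7000 nM in this assay. Given the limit from which it starts, the estimate for compound 4 is expected to lie somewhere between 2500 nM and 30000 nM.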

Compound 4, concentration lethal to 50% of the cells: > 32500 nM
Compound 4 was reported as a limit; the forecaster's own chance of this, stated with the estimate: 20%; middle value at least 4.6-fold (0.66 log units) from the limit.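

In this assay compound 4 gives only a limit, > 32500 nM, and no number. Compound 3 is a limit as well, so no step can be read between compound 3 and compound 4, and the two stand at the same limit: the limit of > 32500 nM in this assay, at which 2 of the 4 values shown sit.

The compounds shown leave open whether methoxy to hydroxy changes the number at all on the core of compound 3, as it does on the core of compound 1.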